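Cyclohexyl in place of benzyl on an amine nitrogen

A few compounds are considered here, and "the series" means these few. Any claim that something is new, unique, unknown or untested is made for them only; others in the source may bear on it.

Compound 1 `O=C1C(Nc2ccc(I)cc2)=CC(=O)c2c1nc1n2[C@H]2OC[C@@H](O)[C@H]2OC1` gives 3890 nM in a functional assay on MCF7 cells (Homo sapiens) for inhibition, read by sulforhodamine B assay (on this read-out lower numbers stand for stronger inhibition and higher numbers for weaker inhibition), on the shared core. Compound 3 `O=C1C(Nc2ccccc2F)=CC(=O)c2c1nc1n2[C@H]2OC[C@@H](O)[C@H]2OC1` gives > 4000 nM in this assay as a limit and not a number. Compound 2 `O=C1C=C(NCc2ccccc2)C(=O)c2c1nc1n2[C@H]2OC[C@@H](O)[C@H]2OC1` stands at > 8000 nM in this assay as a limit too, so no number is known for it.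

The change to compound 4 `O=C1C=C(NC2CCCCC2)C(=O)c2c1nc1n2[C@H]2OC[C@@H](O)[C@H]2OC1`, not yet measured, is cyclohexyl in place of benzyl on an amine nitrogen and reads cyclohexyl in place of benzyl on an amine nitrogen. Among the measured compounds shown here, the one measured step of an at least 1.0-fold higher number from compound 1 to compound 3 (0.01 log units; that floor lies within the scatter) with 2-fluorophenyl in place of 4-iodophenyl has a floor within the scatter and involves neither benzyl nor cyclohexyl, so it bears only loosely on this change. With only an at least 1.0-fold higher number from compound 1 to compound 3 (0.01 log units; that floor lies within the scatter) to go on, no step beyond the scatter is expected in this assay for this change. The expected step of an at least 1.1-fold lower number from compound 2 to compound 4 (0.05 log units; that floor lies within the scatter) is therefore estimated as small. For compound 4 the estimate is 7000 nM with an expected range from 3000 nM to 16000 nM in this read-out, and a limit instead of a number is also possible.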

Compound 4, half-maximal inhibitory concentration: > 8000 nM
Compound 4: no number, only a limit; the forecaster's own chance of this, stated with the estimate: 55%; at least 1.1-fold (0.05 log units) between middle value and limit.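

In this assay compound 4 gives > 8000 nM, a limit and not a number. Among the compounds shown here, compound 2 gives > 8000 nM, also a limit, so no step between compound 2 and compound 4 can be read. The compounds shown leave open whether benzyl or cyclohexyl on the amine nitrogen gives the lower number.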